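The source may hold more compounds than are shown below. What is called first, only, known or untested is meant among the compounds shown, and "the series" means these compounds.

In an ADME assay on L929 cells (Mus musculus) for cytotoxicity, read by resazurin assay, with a stated time of 72 h (a higher number here means a weaker inhibitor, a lower number a stronger inhibitor), compound 1 `O=C(/C=C/c1ccc2c(c1)B(O)OC2)c1ccco1` gives > 10 ug/mL, which is a limit of the assay and not a number. Compound 2 `COc1cccc(C(=O)CCc2ccc3c(c2)B(O)OC3)c1` gives > 10 ug/mL, also a limit. Compound 3 `O=C(/C=C/c1ccc2c(c1)B(O)OC2)c1ccc(Cl)c(Cl)c1` gives > 10 ug/mL, again a limit. All three compounds therefore sit at the same point, (the limit of > 10 ug/mL in this assay, at which 3 of the 3 values shown sit), so compound 1 cannot be ranked against the other two.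

The next compound, compound 4 `O=C(/C=C/c1ccc2c(c1)B(O)OC2)c1ccc(F)cc1`, differs from compound 1 at one place, with 4-fluorophenyl in place of furan-2-yl on a carbonyl carbon. The best guide to this change is compound 3, which also has a six-membered aromatic ring of carbon only on that carbonyl carbon. Compound 3 still reads > 10 ug/mL, and this too is only a limit. No step beyond the usual scatter is therefore expected in this assay, and no clear direction is expected either. The expected change is a step that the limit leaves unreadable from compound 1 to compound 4, an estimate that remains within the scatter. A report of compound 4 as a limit would be the most likely outcome. For compound 4 the estimated value is 12 ug/mL, with an expected range from 6 ug/mL to 30 ug/mL.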

Compound 4, half-maximal inhibitory concentration: > 10 ug/mL
Compound 4 gave a limit, no number (the forecaster's own chance of this, stated with the estimate: 80%); the middle value is on the limit's open side.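

In this assay no step can be read from compound 1 to compound 4, because both values are limits and not numbers: the limit of > 10 ug/mL in this assay, at which 4 of the 4 values shown sit.

The compounds shown leave open how far any of them lies beyond that limit, and whether 4-fluorophenyl in place of furan-2-yl on a carbonyl carbon makes any difference in this assay.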